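Propyl for tert-butyl on the trifluoromethyl compound

This account rests on a few compounds, and the source may have more. Where it says the series, first, only, none or still open, it means among the compounds named here.

In an ADME assay on microsomes from liver (Homo sapiens) for metabolic stability (a lower number here means slower removal, a higher number faster removal of the compound), compound 3 `CC(C)(C)C(Oc1ccc(-n2cc(C(F)(F)F)cn2)cc1)c1ccc(C(=O)NCCC(=O)O)cc1` gives 31 mL/min/kg, within the scatter of compound 2 `CCCC(Oc1ccc(-n2cc3c(n2)CCCC3)cc1)c1ccc(C(=O)NCCC(=O)O)cc1` at 48 mL/min/kg. Compound 1 `CCCC(Oc1ccc(-n2cc(OC)cn2)cc1)c1ccc(C(=O)NCCC(=O)O)cc1` stands at < 8 mL/min/kg, which is a limit of the assay. Compound 4 `CCCC(Oc1ccc(-n2cc(C(F)(F)F)cn2)cc1)c1ccc(C(=O)NCCC(=O)O)cc1` differs from compound 3 by propyl in place of tert-butyl on a saturated chain carbon bound to an aromatic carbon and an oxygen on an aromatic ring, and it keeps the trifluoromethyl group. For the measured compounds named here, no measured step makes this exchange. Going by the values given here, the only measured step, an at least 6.0-fold higher number from compound 1 to compound 2 (0.77 log units; beyond the scatter), joins two propyl compounds, so propyl alone does not fix the number in this assay and the range must stay wide. The expected step is small and leans downward: a 1.9-fold lower number from compound 3 to compound 4 (0.29 log units; within the scatter). Compound 4 is estimated at 16 mL/min/kg, with an expected range of 8 mL/min/kg to 35 mL/min/kg.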

Compound 4, clearance: 16 mL/min/kg
Beside the measured number, compound 4's estimate shows no gap at the digits printed, and the stated range covers the measured number.
By their numbers in this assay, from the lowest: compounds 4, 3 and 2 (each within the scatter of the next, the first and the last beyond it). At a limit, below all of these: compound 1.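

In this assay, propyl in place of tert-butyl on a saturated chain carbon gives a 1.9-fold lower number from compound 3 to compound 4 (0.29 log units; within the scatter), so with trifluoromethyl kept, this exchange stays within the scatter. With propyl held, the group on the aromatic carbon does separate compounds: a 3.0-fold lower number from compound 2 to compound 4 (0.48 log units; beyond the scatter). Trifluoromethyl in place of methoxy gives an at least 2.0-fold higher number from compound 1 to compound 4 (0.30 log units; that floor lies within the scatter), and its size stays unfixed, as compound 1 stands at a limit: the limit of < 8 mL/min/kg in this assay, at which 1 of the 4 values shown sits.

As far as these compounds go, whether the propyl and tert-butyl exchange stays as small with methoxy kept remains open. Cyclopropyl on that chain carbon and an amine in place of trifluoromethyl lie outside the compounds shown.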